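From compound 3 to compound 4: an open-chain replacement

This account rests on a few compounds, and the source may have more. Where it says the series, first, only, none or still open, it means among the compounds named here.

Measured so far in an ADME assay on Huh-7 cells (Homo sapiens) for cytotoxicity, with a stated time of 72 h; a higher number here means that more compound is tolerated, a lower number that less compound is tolerated:
- compound 1 `CC(C)CCn1nc(-c2cncs2)c(O)c(C2=NS(=O)(=O)c3cc(NS(C)(=O)=O)ccc3N2)c1=O` gives > 33000 nM, a limit
- compound 2 `CC(C)CCn1nc(C2CCCCC2)c(O)c(C2=NS(=O)(=O)c3cc(NS(C)(=O)=O)ccc3N2)c1=O` gives > 1000 nM, a limit
- compound 3 `CC(C)CCn1nc(C2=CCCC2)c(O)c(C2=NS(=O)(=O)c3cc(NS(C)(=O)=O)ccc3N2)c1=O` gives > 1000 nM, a limit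

None of these readings is a number. Compound 3 stands at the limit of > 1000 nM in this assay, at which 2 of the 3 values shown sit, alongside compound 2. Compound 1 stands at the limit of > 33000 nM in this assay, at which 1 of the 3 values shown sits.

Compound 4 `C/C(=C\c1nn(CCC(C)C)c(=O)c(C2=NS(=O)(=O)c3cc(NS(C)(=O)=O)ccc3N2)c1O)C(F)(F)F` carries 2-(trifluoromethyl)prop-1-en-1-yl in place of cyclopent-1-en-1-yl on an aromatic carbon, next to the ring nitrogen and ortho to a hydroxy group: 2-(trifluoromethyl)prop-1-en-1-yl in place of cyclopent-1-en-1-yl on an aromatic carbon.

Two measured changes at this same position bear most directly on it. Within the data shown here, the first is a step that the two limits leave unreadable from compound 1 to compound 3. The second is a step that the two limits leave unreadable from compound 2 to compound 3. The remaining change at this position is a step that the two limits leave unreadable from compound 1 to compound 2. No size can be taken from any of them, and none of the three compounds has reached a measured end point in this assay. No direction of change is therefore expected, and no step beyond the usual scatter can be predicted from these data. The expected change is a step that the limit leaves unreadable from compound 3 to compound 4. A further limit is the most likely report for compound 4. The estimate for compound 4 is 5000 nM. The expected range for this compound runs from 1000 nM to 33000 nM.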

Compound 4, half-maximal cytotoxic concentration: > 33000 nM
Compound 4: a limit, no number; the forecaster's own chance of this, stated with the estimate: 90%; middle value at least 6.6-fold (0.81 log units) away from the limit.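

In this assay compound 4 gives > 33000 nM, a limit and not a number. The steps to compound 4 from compound 1, compound 2 and compound 3 all join two limits and cannot be read. The compounds shown leave open whether the groups compared at this position differ at all in this assay.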